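Taking the methyl off compound 2

The compounds below may be only part of what the source reports. "The series", "measured", "known", "first", "only" and "open" are said of these compounds alone.

In an in vitro ADME assay on microsomes from liver (Mus musculus) for pharmacokinetics, read by LC-MS (a higher number here means faster removal of the compound, a lower number slower removal), compound 1 `Cc1cccc2c1nc(C)n2-c1ccc(C(=O)NC2CC2)s1` gives 66 mL/min/kg and compound 2 `Cc1nc2c(F)cccc2n1-c1ccc(C(=O)NC2CC2)s1` gives 37 mL/min/kg and so stands within the scatter of compound 1. Compound 3 `O=C(NC1CC1)c1ccc(-n2cnc3c(F)cccc32)s1` differs from compound 2 by hydrogen in place of methyl on an aromatic carbon and has no measured value yet. Within the data shown here, the only measured step, a 1.8-fold lower number from compound 1 to compound 2 (0.25 log units; within the scatter) for fluoro in place of methyl on an aromatic carbon, lies within the scatter and concerns another place, so it offers only loose guidance. In this assay the expected move is a 1.1-fold higher number from compound 2 to compound 3 (0.03 log units; within the scatter) and nothing beyond the scatter. Compound 3 is estimated at 40 mL/min/kg with a range from 20 mL/min/kg to 75 mL/min/kg as the expected bounds.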

Compound 3, clearance: > 72 mL/min/kg
Compound 3 gave a limit, no number (the forecaster's own chance of this, stated with the estimate: 2%); middle value at least 1.8-fold (0.25 log units) from the limit.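

In this assay compound 3 gives a limit and not a number: the limit of > 72 mL/min/kg in this assay, at which 1 of the 3 values shown sits. Hydrogen in place of methyl on this aromatic carbon, between two ring nitrogen atoms, gives an at least 1.9-fold higher number from compound 2 to compound 3 (0.28 log units; that floor lies within the scatter). Among these compounds, this is the first reading at this position, and it fixes only a floor, so the full size of the step stays unknown.

What the compounds shown leave open is how an ethyl or an amine on this carbon would read in this assay. Also open, on these data alone, is whether the same change would read alike with the methyl of compound 1 in place of the fluoro.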